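The source may report more compounds than this note shows. Statements on the series, on what has been measured and on what is new or still open speak of the compounds shown alone.

Measured so far in a physicochemical assay for solubility, read by HPLC, using the shake flask method, measured as kinetic solubility, with a stated time of 2 h, at pH 7.4; on this read-out lower numbers stand for lower solubility and higher numbers for higher solubility:
- compound 1 `Cc1cc(NCc2ncccn2)n2nc(C)c(-c3ccccc3)c2n1` gives 37900 nM
- compound 2 `Cc1cc(N(C)Cc2ccccn2)n2nc(C)c(-c3ccccc3)c2n1` gives 17500 nM
- compound 3 `COc1ccc(-c2c(C)nn3c(NCc4ccccn4)cc(C)nc23)cc1` gives < 5000 nM

Of the two values that are numbers, compound 1 holds the higher one, and the gap between compound 1 and compound 2 lies beyond the usual scatter of this assay. The value of compound 3 is not a number but a limit: it sits at the limit of < 5000 nM in this assay, at which 1 of the 3 values shown sits. Going by the values given here, no pair of these three compounds differs in only one place, so no single step between measured compounds can be read off, and compound 1 must be taken on its own as the starting point.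

The compound still to be measured is compound 4 `CCN1CCCC1CNc1cc(C)nc2c(-c3ccccc3)c(C)nn12`. Compared with compound 1 the change is this: 1-ethylpyrrolidin-2-yl in place of pyrimidin-2-yl on a saturated chain carbon bound to a nitrogen on an aromatic ring. Among the compounds with values here, since nothing among the measured compounds follows a change of this kind, the expectation for compound 4 rests on compound 1 alone together with the nature of the change. A step upward in this assay is expected, a 2.2-fold higher number from compound 1 to compound 4 (0.35 log units; beyond the scatter), likely larger than the scatter, though the size is uncertain. Compound 4 is therefore estimated at 85000 nM, within a range from 30000 nM to 250000 nM.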

Compound 4, solubility: 172000 nM
Beside the measured number, compound 4's estimate is 2.0-fold (0.31 log units) below it; measured number inside the range.
By their numbers in this assay, from the lowest: compound 2; then compound 1; then compound 4. At a limit, below all of these: compound 3.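

In this assay the place on a saturated chain carbon bound to a nitrogen on an aromatic ring now has its first readable step: 1-ethylpyrrolidin-2-yl in place of pyrimidin-2-yl gives a 4.5-fold higher number from compound 1 to compound 4 (0.66 log units; beyond the scatter). The earlier compounds shown here could not show this, as none of them differed from another in only one place and all carried an aromatic ring at this spot, whereas here a six-membered aromatic ring with 2 hetero atoms gives way to a five-membered non-aromatic ring with 1 hetero atom and the number still rises. Nothing measured among these compounds accounts for the size or direction of this step.

Going by these compounds alone, the single step changes the ring and adds the ethyl group together, so it cannot say which part carries the rise; a pyrrolidin-2-yl without the ethyl, a 1-methylpyrrolidin-2-yl or a piperidin-2-yl would each separate these parts. Nor can it say whether the same exchange would move the number in the same way on a core bearing another group, such as a methoxy-substituted phenyl ring.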